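A few compounds are considered here, and "the series" means these few. Any claim that something is new, unique, unknown or untested is made for them only; others in the source may bear on it.

Of the compounds shown here, three built on a shared core have been tested in a functional assay on MT4 cells (Homo sapiens) for cytotoxicity, read by MTT assay (a higher number here means that more compound is tolerated, a lower number that less compound is tolerated), and none of them gives an exact number. Compound 1 `COc1ccc(CSc2nc(O)c(C)c(Cc3c(Cl)cccc3Cl)n2)cc1OC` reports > 55000 nM, which is a limit of the assay. Compound 2 `Cc1c(O)nc(SCc2ccc(Cl)cc2)nc1Cc1c(Cl)cccc1Cl` reports > 59000 nM, also a limit. Compound 3 `COc1cc(CSc2nc(O)c(C)c(Cc3c(F)cccc3F)n2)cc(OC)c1` reports > 60000 nM, again a limit, so it stands as one of three compounds known only by limits.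

Compound 4 `COc1cc(CSc2nc(O)c(C)c(Cc3c(Cl)cccc3Cl)n2)cc(OC)c1` has not yet been measured. The change from compound 3 to compound 4 is 2,6-dichlorophenyl in place of 2,6-difluorophenyl on a saturated chain carbon bound to an aromatic carbon. Compound 1 already carries the 2,6-dichlorophenyl group and shows the limit > 55000 nM. Compound 2 carries the same group and shows the limit > 59000 nM. On this basis, no step beyond the usual scatter is expected in this assay, in either direction, and the assay may again report only a limit. The expected step is an at least 1.0-fold lower number from compound 3 to compound 4 (0.03 log units; that floor lies within the scatter). Compound 4 is estimated at 55000 nM, with an expected range of 30000 nM to 75000 nM.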

Compound 4, half-maximal cytotoxic concentration: > 55000 nM
Compound 4: no number, only a limit; the forecaster's own chance of this, stated with the estimate: 85%; the middle value lies on the limit itself.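

For the compounds shown here, compound 3 and compound 4 are both known in this assay only by limits, so no step between them can be read. The compounds shown leave open what exact concentration any of them tolerates, and whether 2,6-dichlorophenyl in place of 2,6-difluorophenyl changes it.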